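Chlorine shift on the aryl carbinol series

This account rests on a few compounds, and the source may have more. Where it says the series, first, only, none or still open, it means among the compounds named here.

- compound 1 `CC(C)=CC(O)C1=CC(=O)c2ccccc2C1=O`: 5200 nM
- compound 2 `O=C1C=C(C(O)c2ccc(Cl)cc2)C(=O)c2ccccc21`: 3000 nM
- compound 3 `Cc1cc(Cl)ccc1C(O)C1=CC(=O)c2ccccc2C1=O`: 3400 nM

All three values come from a functional assay on WHCO1 cells (Homo sapiens) for cytotoxicity, read by MTT assay, with a stated time of 24 h (on this read-out lower numbers stand for stronger inhibition and higher numbers for weaker inhibition), where compound 2 stands within the scatter of both compound 1 and compound 3. Compound 4 `O=C1C=C(C(O)c2cccc(Cl)c2)C(=O)c2ccccc21` differs from compound 2 as follows: 3-chlorophenyl in place of 4-chlorophenyl on a saturated chain carbon bound to a double-bonded ring carbon and an oxygen on a saturated carbon, with 3-chlorophenyl in place of 4-chlorophenyl on a saturated chain carbon bound to a double-bonded ring carbon and an oxygen on a saturated carbon.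

Among the compounds with values here, two measured steps bear on this: a 1.7-fold lower number from compound 1 to compound 2 (0.24 log units; within the scatter), and a 1.1-fold higher number from compound 2 to compound 3 (0.05 log units; within the scatter). Neither moves the chlorine, so the evidence is indirect, but neither step left the scatter. No step beyond the scatter is expected in this assay. The expected step is a 1.1-fold higher number from compound 2 to compound 4 (0.03 log units; within the scatter). For compound 4 the estimate is 3200 nM, with an expected range of 1600 nM to 6400 nM.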

Compound 4, half-maximal inhibitory concentration: 7300 nM
For compound 4 the middle estimate is 2.3-fold (0.36 log units) below the measured one; measured number outside the range, above it.
By their numbers in this assay, from the lowest: compounds 2, 3, 1 and 4 (each within the scatter of the next, the first and the last beyond it).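

Where the chlorine sits on the phenyl ring counts in this assay: 3-chlorophenyl in place of 4-chlorophenyl gives a 2.4-fold higher number from compound 2 to compound 4 (0.39 log units; beyond the scatter), the first step in the series beyond the scatter. 3-chlorophenyl in place of 2-methylprop-1-en-1-yl gives a 1.4-fold higher number from compound 1 to compound 4 (0.15 log units; within the scatter), so a chlorophenyl group at this place does not by itself separate from that chain. Nothing available explains the effect of the chlorine shift. Going by these compounds, whether a methoxy group or an amine on the phenyl ring would depend on its ring position in the same way remains open.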